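Triazole substituent swap on a flavanone scaffold

The source may hold more compounds than are shown below. What is called first, only, known or untested is meant among the compounds shown, and "the series" means these compounds.

Three compounds have been measured in a functional assay on RAW264.7 cells (Mus musculus) for inhibition, read by Griess assay, with stated times of 2 h and 24 h; a lower number here means a stronger inhibitor, a higher number a weaker inhibitor:
compound 1 `CCCCn1cc(COc2cc(O)c3c(c2)O[C@H](c2ccc(OC)c(O)c2)C/C3=N\O)nn1` gives 8900 nM;
compound 2 `COc1ccc([C@@H]2CC(=O)c3c(O)cc(OCc4cn(Cc5ccccc5F)nn4)cc3O2)cc1O` gives 7320 nM;
compound 3 `COc1ccc([C@@H]2C/C(=N\O)c3c(O)cc(OCc4cn(C5CCCC5)nn4)cc3O2)cc1O` gives 6880 nM.

Compound 2 sits second highest of the three numbers, but its nearest neighbour is compound 3 and its furthest is compound 1, and both gaps are within the scatter, so the three compounds cannot be told apart on these values.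

Compound 4 `COc1ccc([C@@H]2CC(=O)c3c(O)cc(OCc4cn(C5CCC5)nn4)cc3O2)cc1O` is not yet measured. It differs from compound 2 by cyclobutyl in place of 2-fluorobenzyl on an aromatic nitrogen. Among the measured compounds shown here, the only measured step that bears on this place is a 1.3-fold lower number from compound 1 to compound 3 (0.11 log units; within the scatter), also a change of the group on the aromatic nitrogen of the triazole, and it stayed within the scatter. With cyclobutyl in place of 2-fluorobenzyl, the change from compound 2 to compound 4 is therefore expected to be a 1.0-fold lower number from compound 2 to compound 4 (0.02 log units; within the scatter), with no direction beyond the scatter. In this assay compound 4 is estimated at 7000 nM, with a range from 3500 nM to 14000 nM.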

Compound 4, half-maximal inhibitory concentration: 15300 nM
Estimate against measurement, compound 4: 2.2-fold (0.34 log units) below; measured number above the stated range.
By their numbers in this assay, from the lowest: compounds 3, 2, 1 and 4 (each within the scatter of the next, the first and the last beyond it).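

The group on the aromatic nitrogen of the triazole now shows a difference in this assay: cyclobutyl in place of 2-fluorobenzyl gives a 2.1-fold higher number from compound 2 to compound 4 (0.32 log units; beyond the scatter), whereas the earlier change of butyl to cyclopentyl gave only a 1.3-fold lower number from compound 1 to compound 3 (0.11 log units; within the scatter). The position therefore does not accept every group equally, although the step is modest and marks a single exchange of a six-membered aromatic ring of 8 heavy atoms for a four-membered non-aromatic ring of 4 heavy atoms. The compounds shown offer no measurement that accounts for this step.

Going by these compounds, it remains open whether the higher number of compound 4 follows from losing the fluorine, the aromatic ring or both, which a plain benzyl group would help to separate. Also open, on these data alone, are how a 2-aminoethyl group would fare here and whether the step would carry over to the core of compound 3.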